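From Bromo to Nitro on a Shared Core

The source may hold more compounds than are shown below. What is called first, only, known or untested is meant among the compounds shown, and "the series" means these compounds.

Among the compounds with values here, in a functional assay on B16-F10 cells (Mus musculus) for antiproliferative activity, read by MTT assay, with a stated time of 48 h (on this read-out higher numbers stand for weaker inhibition and lower numbers for stronger inhibition), compound 1 `CC(=O)N1N=C(c2ccc(Cl)cc2)CC1c1ccc2c(c1)OCCO2` gives 47300 nM and compound 2 `CC(=O)N1N=C(c2ccc(Br)cc2)CC1c1ccc2c(c1)OCCO2` gives 44100 nM, so compound 2 stands level with its only measured neighbour. Within the data shown here, the single measured step, a 1.1-fold lower number from compound 1 to compound 2 (0.03 log units; within the scatter), is bromo in place of chloro on an aromatic carbon. Compound 3 `CC(=O)N1N=C(c2ccc([N+](=O)[O-])cc2)CC1c1ccc2c(c1)OCCO2` instead has nitro in place of bromo on an aromatic carbon, para to a large group: nitro in place of bromo on an aromatic carbon. Among the measured compounds shown here, that step from compound 1 to compound 2 bears on this change only loosely, since no measured compound carries a nitro group. It offers no ground for expecting a shift in either direction, so no step beyond the scatter is expected in this assay. The expected step is a 1.1-fold lower number from compound 2 to compound 3 (0.04 log units; within the scatter). For compound 3, the estimated value is 40000 nM, with an expected range of 15000 nM to 100000 nM.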

Compound 3, half-maximal inhibitory concentration: 57800 nM
Estimate against measurement, compound 3: 1.4-fold (0.16 log units) below; low and high end bracket the measured number.
By their numbers in this assay, from the lowest: compounds 2, 1 and 3 (each within the scatter of the next).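

In this assay, nitro in place of bromo on an aromatic carbon, para to a large group, gives a 1.3-fold higher number from compound 2 to compound 3 (0.12 log units; within the scatter), while nitro in place of chloro gives a 1.2-fold higher number from compound 1 to compound 3 (0.09 log units; within the scatter). Within the data shown here, this position had so far held only chloro and bromo, and it now also takes nitro, which brings 3 heavy atoms and 2 hydrogen-bond acceptors where bromo had 1 heavy atom and none, with neither step going beyond the scatter. No measurement accompanies these compounds that could say what lies behind the result.

The compounds shown leave open whether an amine, a carboxylic acid or a longer chain in this place would produce a step beyond the scatter. They also leave open how the shared core would respond to a change in any other place.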